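From Compound 2 to Compound 4: Adding a Cyclopropyl

A few compounds are considered here, and "the series" means these few. Any claim that something is new, unique, unknown or untested is made for them only; others in the source may bear on it.

In a functional assay on cells (Neutrophil, Homo sapiens) for inhibition, with a stated time of 10 min (on this read-out lower numbers stand for stronger inhibition and higher numbers for weaker inhibition), compound 2 `NC(=O)c1cnn2c1N(C(=O)Nc1cccc(F)c1)C(c1ccccc1)C2` gives 1.2 nM, the lowest number measured, while compound 1 `NC(=O)c1cnn2c1N(C(=O)Nc1ccccc1F)C(c1ccccc1)C2` gives 6.2 nM, a change of a 5.2-fold lower number from compound 1 to compound 2 (0.71 log units; beyond the scatter). Compound 3 `NC(=O)c1cnn2c1N(C(=O)Nc1cccc3ccccc13)C(c1ccccc1)C2` gives only a limit of the assay, > 1000 nM. Compound 4 `O=C(NC1CC1)c1cnn2c1N(C(=O)Nc1cccc(F)c1)C(c1ccccc1)C2` differs from compound 2 by cyclopropyl in place of hydrogen on an amide-type nitrogen, turning carbamoyl into cyclopropylcarbamoyl. Among the compounds with values here, no measured step alters the carbamoyl group, so the evidence is indirect. Exchanging the fluorophenyl group for naphthalen-1-yl gave an at least 830-fold higher number from compound 2 to compound 3 (2.92 log units; beyond the scatter) and an at least 160-fold higher number from compound 1 to compound 3 (2.20 log units; beyond the scatter), which shows that single changes can matter greatly in this series. A moderate to large rise is therefore expected, with an estimated 21-fold higher number from compound 2 to compound 4 (1.32 log units; beyond the scatter). For compound 4 the expected value is 25 nM, within an estimated range of 2.5 nM to 400 nM.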

Compound 4, half-maximal inhibitory concentration: > 1000 nM
Compound 4: a limit, no number; the forecaster's own chance of this, stated with the estimate: 20%; middle value at least 40-fold (1.60 log units) from the limit.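

Cyclopropyl in place of hydrogen on an amide-type nitrogen, a place no earlier step touched, gave in this assay an at least 830-fold higher number from compound 2 to compound 4 (2.92 log units; beyond the scatter). The carbamoyl group, like the fluorophenyl group, is therefore a place where a single change can abolish measurable inhibition. The value of compound 4 is a limit and not a number, so this step has a floor but no measured size: the limit of > 1000 nM in this assay, at which 2 of the 4 values shown sit.

As far as these compounds go, whether any replacement of this hydrogen has the same result stays open. A methyl group or a longer chain such as propyl on this nitrogen could separate the two cases.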